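Swapping the aryl on the hydrazone carbon of a urea series

A few compounds are considered here, and "the series" means these few. Any claim that something is new, unique, unknown or untested is made for them only; others in the source may bear on it.

Measured compounds:
Compound 1, `COc1ccc(/C=N/NC(=O)Nc2ccc(Oc3ccnc(-c4nncn4CCN(C)C)c3)c(F)c2)c(OC)c1`, 1570 nM
Compound 2, `CN(C)CCn1cnnc1-c1cc(Oc2ccc(NC(=O)N/N=C/c3ccc(F)cc3F)cc2F)ccn1`, 1930 nM

Both compounds share a core and differ only in the aromatic group attached to the carbon that is double-bonded to nitrogen. In a functional assay on NCI-H460 cells (Homo sapiens) for cytotoxicity, read by MTT assay, with a stated time of 72 h (on this read-out higher numbers stand for weaker inhibition and lower numbers for stronger inhibition), compound 1 gives 1570 nM, and compound 2 gives 1930 nM. The step of a 1.2-fold higher number from compound 1 to compound 2 (0.09 log units; within the scatter) shows that changing that aryl group left the read-out essentially unchanged. Compound 2 therefore stands with the higher of the two numbers, but the gap to compound 1 is within the scatter, so neither can be called stronger or weaker.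

Compound 3, `CN(C)CCn1cnnc1-c1cc(Oc2ccc(NC(=O)N/N=C/c3cccc(Cl)c3Cl)cc2F)ccn1`, has not yet been measured. It differs from compound 2 by 2,3-dichlorophenyl in place of 2,4-difluorophenyl on a carbon with a double bond to nitrogen. Going by the values given here, the one step that bears on this, a 1.2-fold higher number from compound 1 to compound 2 (0.09 log units; within the scatter), was within the scatter, and nothing more is known about halogen patterns on this ring. The expected step of a 1.0-fold lower number from compound 2 to compound 3 (0.01 log units; within the scatter) is therefore none beyond the scatter. Compound 3 is estimated at 1900 nM, in the range 900 nM to 4000 nM.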

Compound 3, half-maximal inhibitory concentration: 72 nM
Compound 3: the middle estimate sits 26-fold (1.42 log units) above what was measured; the whole stated range lies above it.
By their numbers in this assay, from the lowest: compound 3; then compounds 1 and 2 (each within the scatter of the next).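

In this assay, the aryl group on the carbon with a double bond to nitrogen turns out to matter a great deal: 2,3-dichlorophenyl in place of 2,4-difluorophenyl gives a 27-fold lower number from compound 2 to compound 3 (1.43 log units; beyond the scatter), and 2,3-dichlorophenyl in place of 2,4-dimethoxyphenyl gives a 22-fold lower number from compound 1 to compound 3 (1.34 log units; beyond the scatter). The earlier pair differed only within the scatter and gave no sign of this, yet here a swap that keeps the same count of heavy atoms and the same carbon-only aromatic ring moves the number far beyond the scatter. Nothing measured here accounts for the size of this step.

The change replaces the halogen and its pattern on the ring together, so the compounds shown cannot tell which of the two carries the step. A 2,4-dichlorophenyl or 2,3-difluorophenyl group at this place would separate them.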